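Notes on the step from compound 3 to compound 4

The source may report more compounds than this note shows. Statements on the series, on what has been measured and on what is new or still open speak of the compounds shown alone.

Values in a physicochemical assay for solubility, read by HPLC, measured as thermodynamic solubility, with a stated time of 4 h, at pH 6.8 (on this read-out lower numbers stand for lower solubility and higher numbers for higher solubility), so far:
- compound 1 `Cn1c(COc2cccc(C(=O)O)c2)nc2ccc(Oc3ccccn3)cc21` gives 62 ug/mL
- compound 2 `Cn1c(COc2cccc(C(=O)O)c2)nc2ccc(Oc3ccc(Cl)cn3)cc21` gives 17 ug/mL
- compound 3 `Cn1c(COc2cccc(C(=O)O)c2)nc2ccc(Oc3cc(Cl)ccn3)cc21` gives 11 ug/mL

Two steps fix the standing of compound 3 in this assay with a 1.5-fold lower number from compound 2 to compound 3 (0.19 log units; within the scatter) within the scatter and a 5.6-fold lower number from compound 1 to compound 3 (0.75 log units; beyond the scatter) beyond it. Compound 4 `Cc1cccc(Oc2ccc3nc(COc4cccc(C(=O)O)c4)n(C)c3c2)n1` carries 6-methylpyridin-2-yl in place of 4-chloropyridin-2-yl on an oxygen on an aromatic ring, with 6-methylpyridin-2-yl in place of 4-chloropyridin-2-yl on an oxygen on an aromatic ring as the counted difference. For the measured compounds named here, no methyl analogue has been measured. The nearest guide is chloro in place of hydrogen, with a 3.6-fold lower number from compound 1 to compound 2 (0.56 log units; beyond the scatter) as one modest step and a 5.6-fold lower number from compound 1 to compound 3 (0.75 log units; beyond the scatter) as the other. A small partial recovery is expected, with a 2.2-fold higher number from compound 3 to compound 4 (0.34 log units; beyond the scatter) as the estimated step in this assay and modest confidence in it. Compound 4 is estimated at 24 ug/mL with a range of 10 ug/mL to 60 ug/mL for now.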

Compound 4, solubility: 92 ug/mL
The estimate for compound 4 lay 3.8-fold (0.58 log units) below the measured number; measured number above the stated range.
By their numbers in this assay, from the lowest: compounds 3 and 2 (each within the scatter of the next); then compounds 1 and 4 (each within the scatter of the next).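

In this assay, the added methyl group gives a 1.5-fold higher number from compound 1 to compound 4 (0.17 log units; within the scatter), whereas both chloro replacements moved the number beyond the scatter. The 6-methylpyridin-2-yl group also stands clear of both chloro compounds, with an 8.4-fold higher number from compound 3 to compound 4 (0.92 log units; beyond the scatter) and a 5.4-fold higher number from compound 2 to compound 4 (0.73 log units; beyond the scatter), so a substituent on this pyridine ring need not lower the number.

Going by these compounds, since methyl and chloro occupy different ring places here, 6-chloropyridin-2-yl and 4-methylpyridin-2-yl remain open, as do methoxy and amine substituents. Nothing available explains these differences.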